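From 4-Methoxyphenyl to 3-Fluorophenyl: Expecting Compound 4

This account rests on a few compounds, and the source may have more. Where it says the series, first, only, none or still open, it means among the compounds named here.

Among the compounds with values here, compound 3 `COc1ccc(-c2c(C)nn(-c3nc(-c4ccc(Cl)c(Cl)c4)c(SC(C)C)s3)c2C(=O)O)cc1` gives 2100 nM in a functional assay on BJAB cells (Homo sapiens) for antiproliferative activity, with a stated time of 4 days (on this read-out lower numbers stand for an effect already at smaller amounts and higher numbers for an effect only at larger amounts of compound), the second highest of the three numbers measured so far. Compound 2 `COc1cc(-c2c(C)nn(-c3nc(-c4ccc(Cl)c(Cl)c4)c(SC(C)C)s3)c2C(=O)O)cc(C(F)(F)F)c1` gives 1380 nM, and a 1.5-fold higher number from compound 2 to compound 3 (0.18 log units; within the scatter). Compound 1 `Cc1ccc(-c2c(C)nn(-c3nc(-c4ccc(Cl)c(Cl)c4)c(SC(C)C)s3)c2C(=O)O)cc1` gives 3800 nM, and a 1.8-fold lower number from compound 1 to compound 3 (0.26 log units; within the scatter). Compound 4 `Cc1nn(-c2nc(-c3ccc(Cl)c(Cl)c3)c(SC(C)C)s2)c(C(=O)O)c1-c1cccc(F)c1` differs from compound 3 in one place: 3-fluorophenyl in place of 4-methoxyphenyl on an aromatic carbon. Within the data shown here, no measured step places fluorine on this aryl group. Among the measured compounds shown here, the only step in this assay beyond the scatter is a 2.8-fold lower number from compound 1 to compound 2 (0.44 log units; beyond the scatter), and it is modest; the other exchanges on this aryl group stay within the scatter. A change within the scatter is therefore expected: a 1.2-fold higher number from compound 3 to compound 4 (0.08 log units; within the scatter). Compound 4 is estimated at 2500 nM, with a range from 1000 nM to 6500 nM.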

Compound 4, half-maximal effective concentration: 900 nM
Compound 4: middle estimate off by 2.8-fold (0.44 log units), on the high side; measured number outside the range, below it.
By their numbers in this assay, from the lowest: compounds 4, 2, 3 and 1 (each within the scatter of the next, the first and the last beyond it).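

In this assay, within the data shown here, the 3-fluorophenyl group brings a 2.3-fold lower number from compound 3 to compound 4 (0.37 log units; beyond the scatter) and so shows that an exchange of 4-methoxyphenyl at this position can move the number beyond the scatter, which no earlier step from compound 3 did. The same group also gives a 4.2-fold lower number from compound 1 to compound 4 (0.63 log units; beyond the scatter) and, within the scatter, a 1.5-fold lower number from compound 2 to compound 4 (0.19 log units; within the scatter) with a far simpler aryl group than the 3-methoxy-5-(trifluoromethyl)phenyl. No evidence bears on why this exchange has this effect.

Going by these compounds, whether the fluorine itself or its place on the ring matters stays open, and so does how a 4-fluorophenyl or a plain phenyl group would read here.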